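Replacing Isopropoxy with Isobutylamino on the Carbonyl Carbon

The compounds below may be only part of what the source reports. "The series", "measured", "known", "first", "only" and "open" are said of these compounds alone.

Measured compounds in a functional assay on the whole organism for inhibition, with Brassica rapa subsp. chinensis as the target, with a stated time of 3 days, tested at 100 ppm; a higher number here means more inhibition of growth at the concentration tested, a lower number less inhibition of growth:
compound 1, `C=CCNC(=O)/C=C/c1ccccc1`, gives 64%
compound 2, `CCCOC(=O)/C=C/c1ccccc1`, gives 7%
compound 3, `CC(C)OC(=O)/C=C/c1ccccc1`, gives 2%

Compound 3 holds the lowest of the three numbers. Its nearest neighbour is compound 2, and the step of a number 5 percentage points lower from compound 2 to compound 3 (within the scatter) lies within the scatter, so the two cannot be told apart. Its furthest neighbour is compound 1, and the step of a number 62 percentage points lower from compound 1 to compound 3 (beyond the scatter) is beyond the scatter.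

Compound 4, `CC(C)CNC(=O)/C=C/c1ccccc1`, has not yet been measured in this assay. It differs from compound 3 by isobutylamino in place of isopropoxy on a carbonyl carbon. Within the data shown here, two measured steps bear on this: a number 57 percentage points lower from compound 1 to compound 2 (beyond the scatter) and a number 62 percentage points lower from compound 1 to compound 3 (beyond the scatter), each a large drop when allylamino gave way to propoxy or isopropoxy. The change to compound 4 runs the other way, from isopropoxy back to an amino group, so a large rise is expected. The group entering is isobutylamino rather than allylamino, which adds some uncertainty. Compound 4 is therefore estimated at 55%, between 30% and 80%, an expected step of a number 53 percentage points higher from compound 3 to compound 4 (beyond the scatter).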

Compound 4, percent growth inhibition at one concentration: 78%
For compound 4 the middle estimate is 23 percentage points below the measured one, within the range that was stated.
By their numbers in this assay, from the lowest: compounds 3 and 2 (each within the scatter of the next); then compound 1; then compound 4.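

In this assay the high number proves not to be tied to allylamino alone: isobutylamino on the carbonyl carbon gives a number 76 percentage points higher from compound 3 to compound 4 (beyond the scatter) against isopropoxy and a number 71 percentage points higher from compound 2 to compound 4 (beyond the scatter) against propoxy, so a second amino group also stands far above both oxygen-linked groups. The amino group's chain also counts, though far less than the change of linking atom: isopropyl in place of vinyl on the saturated chain carbon bound to the amide-type nitrogen gives a number 14 percentage points higher from compound 1 to compound 4 (beyond the scatter) and a modest step. Nothing available here accounts for either difference.

The compounds shown leave open whether a dimethylamino group, which has no amide hydrogen, would keep the high inhibition of growth. Going by these compounds, it is also open how far the trend in the chain extends, for instance to n-butylamino or to an anilino group.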